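Piperidine swap on the compound 2 scaffold

The compounds below may be only part of what the source reports. "The series", "measured", "known", "first", "only" and "open" are said of these compounds alone.

compound 1 `COc1cc(C)c(S(=O)(=O)N(C)CCOCC(=O)N2CCC(C(C)(C)CN(C)C)CC2)c(C)c1`: 3.8%
compound 2 `COc1cc(C)c(S(=O)(=O)N(C)CCOCC(=O)N2CCN(CC3CCN(C)CC3)CC2)c(C)c1`: 16%

In an in vivo ADME assay on the whole organism (strain Sprague-Dawley) for pharmacokinetics, with Rattus norvegicus as the target, at a dose of 10 mg/kg by the oral route (on this read-out higher numbers stand for higher oral bioavailability and lower numbers for lower oral bioavailability), compound 2 gives 16% and stands highest of the two measured compounds, with compound 1 lower by a gap beyond the scatter. Compound 3 `CCN1CCC(N2CCN(C(=O)COCCN(C)S(=O)(=O)c3c(C)cc(OC)cc3C)CC2)CC1` is the next to be read. It has the same atoms as compound 2, joined differently: 1-ethylpiperidin-4-yl in place of (1-methylpiperidin-4-yl)methyl on an amine nitrogen in a ring places 1-ethylpiperidin-4-yl where (1-methylpiperidin-4-yl)methyl stood, on an amine nitrogen in a ring. Among the measured compounds shown here, no measured pair differs in one place only, so the series offers no direct precedent for this change. The expectation in this assay is therefore anchored on compound 2 at 16% and assumes no shift beyond the scatter, with no firm direction. The estimated step is a number 2 percentage points lower from compound 2 to compound 3 (within the scatter) and stays within the scatter. The estimate for compound 3 is 14% with an expected range from 5% to 28% as a working figure.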

Compound 3, oral bioavailability: 12%
Compound 3: the middle estimate sits 2 percentage points above what was measured, within the range that was stated.
By their numbers in this assay, from the lowest: compounds 1, 3 and 2 (each within the scatter of the next, the first and the last beyond it).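

In this assay, among the compounds shown here, placing 1-ethylpiperidin-4-yl where (1-methylpiperidin-4-yl)methyl stood, on an amine nitrogen in a ring, gives the first single-place step: a number 4 percentage points lower from compound 2 to compound 3 (within the scatter). For this one pair, the same atoms can be joined differently at this position without a shift beyond the scatter, and both groups keep one six-membered non-aromatic ring with 1 hetero atom. The data hold no measurement that could account for the size of this step.

Open, on these data alone, is what a piperidin-4-yl group with no alkyl on its ring nitrogen, or a longer chain between the two rings, would give at this amine nitrogen. Compound 1 differs from compound 2 and compound 3 in more than one place, so it gives no reading on this position.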